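The source may hold more compounds than are shown below. What is called first, only, known or untested is meant among the compounds shown, and "the series" means these compounds.

Notes on the solubility series.

Of the compounds shown here, three of the shared core have been measured in a physicochemical assay for solubility, read by spectrophotometry, in phosphate buffer, with a stated time of 2 h, at pH 7.4; on this read-out lower numbers stand for lower solubility and higher numbers for higher solubility. Compound 1 `COc1ccc2[nH]c(C(=O)N3CC(=O)N(Cc4ccccc4)[C@@H](COc4ccccc4)C3)cc2c1` gives 12200 nM in this assay. Compound 2 `COc1ccc2[nH]c(C(=O)N3CC(=O)N(Cc4cc5ccccc5[nH]4)[C@@H](Cc4ccccc4)C3)cc2c1` gives 11000 nM; its number and that of compound 1 lie within the scatter of each other, so no order between them can be stated. Compound 3 `COc1cccc(CN2C(=O)CN(C(=O)c3cc4cc(OC)ccc4[nH]3)C[C@@H]2Cc2ccccn2)c1` gives 57900 nM, a clearly higher number than compound 1, the gap being beyond the scatter. Compound 1 thus stands second highest of the three numbers, close to compound 2 and well apart from compound 3.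

The next compound, compound 4 `COc1ccc2[nH]c(C(=O)N3CC(=O)N(Cc4ccccc4)[C@@H](CN4CCN(c5ccccn5)CC4)C3)cc2c1`, differs from compound 1 in one place: 4-(pyridin-2-yl)piperazin-1-yl in place of phenoxy on a saturated chain carbon bound to a saturated ring carbon. Among the measured compounds shown here, no pair of measured compounds shows this change, so the size of the step has no measured precedent in the set.

For the measured compounds named here, the expectation for compound 4 in this assay is a step of a 3.3-fold higher number from compound 1 to compound 4 (0.52 log units; beyond the scatter) upward from compound 1, of a size that should be beyond the scatter but is uncertain because the only comparison available, from compound 1 at 12200 nM to compound 3 at 57900 nM, involves several changes at once. Compound 4 is estimated at 40000 nM, with a range from 12000 nM to 130000 nM.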

Compound 4, solubility: 30200 nM
For compound 4 the middle estimate is 1.3-fold (0.12 log units) above the measured one; measured number inside the range.
By their numbers in this assay, from the lowest: compounds 2 and 1 (each within the scatter of the next); then compounds 4 and 3 (each within the scatter of the next).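

In this assay, the place on a saturated chain carbon bound to a saturated ring carbon now has its first one-place comparison: 4-(pyridin-2-yl)piperazin-1-yl in place of phenoxy gives a 2.5-fold higher number from compound 1 to compound 4 (0.39 log units; beyond the scatter), a modest step. The entering group has 12 heavy atoms and 3 hydrogen-bond acceptors against 7 and 1 for phenoxy, neither group carries a net charge, and this single step does not separate which of these differences goes with the higher number. Nothing at hand accounts for the step.

Going by these compounds, it remains open whether a smaller amine at the same place, such as dimethylamino or morpholin-4-yl, or a piperazin-1-yl without the pyridin-2-yl, would give a step of similar size, and how a carboxylic acid there would compare. On these data alone, it is also open whether the step carries over when other parts of the shared core differ, as they do in compound 2 and compound 3.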